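This account rests on a few compounds, and the source may have more. Where it says the series, first, only, none or still open, it means among the compounds named here.

Working notes on the series in a functional assay on DU-145 cells (Homo sapiens) for cytotoxicity, read by trypan blue exclusion, with a stated time of 96 h; a lower number here means a stronger inhibitor, a higher number a weaker inhibitor.

Of the compounds shown here, three carry numbers so far. Compound 1 `COc1ccc(CS(=O)(=O)/C=C/c2ccccc2OC)cc1N` gives 7500 nM in this assay. Compound 2 `COc1cc(OC)c(/C=C/SCc2ccc(OC)c(N)c2)c(OC)c1` gives 50 nM. Compound 3 `COC(=O)CNc1cc(CS(=O)(=O)/C=C/c2c(OC)cc(OC)cc2OC)ccc1OC` gives 100 nM. On these numbers compound 3 stands second highest of the three; its nearest neighbour is compound 2, whose number is lower by a margin that lies within the usual scatter, so no order between compound 2 and compound 3 can be read from them. Compound 1 lies furthest away, with a number well beyond the scatter above that of compound 3. Among the measured compounds shown here, no pair among the measured compounds differs in a single place, so no step between measured compounds is available.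

Compound 4 `COc1ccc(C(Nc2cc(CS(=O)(=O)/C=C/c3c(OC)cc(OC)cc3OC)ccc2OC)C(=O)O)cc1` is not yet measured. It differs from compound 3 in one place: carboxy(4-methoxyphenyl)methyl in place of (methoxycarbonyl)methyl on a nitrogen on an aromatic ring

For the measured compounds named here, with no comparable step among the measured compounds to lean on, the expectation for compound 4 rests on compound 3 alone. The step from compound 3 to compound 4 is expected to be a modest weakening, a 2.5-fold higher number from compound 3 to compound 4 (0.40 log units; beyond the scatter), though a result within the scatter cannot be excluded. Compound 4 is therefore estimated at 250 nM in this assay, with a range from 60 nM to 1000 nM, anchored on compound 3 at 100 nM.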

Compound 4, half-maximal inhibitory concentration: 100 nM
Compound 4: the middle estimate sits 2.5-fold (0.40 log units) above what was measured, and the stated range covers the measured number.
By their numbers in this assay, from the lowest: compounds 2, 3 and 4 (each within the scatter of the next); then compound 1.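

Among the compounds shown here, this is the first step that can be read at a single place: on a nitrogen on an aromatic ring, carboxy(4-methoxyphenyl)methyl in place of (methoxycarbonyl)methyl gives no change at the digits printed from compound 3 to compound 4 (within the scatter) in this assay. The entering group brings a six-membered aromatic ring of carbon only and a hydrogen-bond donor that the leaving group lacks, and this larger group leaves the number within the scatter, so this position on the core of compound 3 can carry either group with no readable difference in this read-out. No measurement at hand bears on why the number holds across this change.

On these data alone, the step alters the carboxy part and the 4-methoxyphenyl part at once, so what each contributes on its own stays open; a plain carboxymethyl or a benzyl on the same nitrogen would separate the two. Also open, as far as these compounds go, is how a free amine at this place compares on the core of compound 3, since compound 1 and compound 2 carry one but differ from compound 3 elsewhere as well.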